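The source may report more compounds than this note shows. Statements on the series, on what has been measured and on what is new or still open speak of the compounds shown alone.

Compound 1 `CCCn1c(=O)[nH]c2nc(-c3ccc(S(=O)(=O)N4CCN(C(C)c5ccccc5)CC4)cc3)[nH]c2c1=O` carries a 1-phenylethyl group on the ring amine nitrogen. In an assay on CHO cells for displacement of a labelled ligand from adenosine receptor A1 (Homo sapiens), read by scintillation counting, with a stated time of 90 min, in the presence of a further agent that is not named here (a lower number here means a stronger inhibitor, a higher number a weaker inhibitor), compound 1 gives only a limit, >= 1000 nM. Compound 2 `CCCn1c(=O)[nH]c2nc(-c3ccc(S(=O)(=O)N4CCN(Cc5ccc(Br)cc5)CC4)cc3)[nH]c2c1=O` carries 4-bromobenzyl at that nitrogen instead. In this assay compound 2 likewise gives only a limit, > 1000 nM. The step that the two limits leave unreadable from compound 1 to compound 2 therefore cannot be read in size, since one value sits at the limit of > 1000 nM in this assay, at which 1 of the 2 values shown sits, and the other at the limit of >= 1000 nM in this assay, at which 1 of the 2 values shown sits. Going by the values given here, compound 2 thus stands at a limit, and the one further value shown is a limit too, so no ordering within the pair can be stated.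

Compound 3 `CCCn1c(=O)[nH]c2nc(-c3ccc(S(=O)(=O)N4CCN(c5ccccc5Cl)CC4)cc3)[nH]c2c1=O` differs from compound 2 by 2-chlorophenyl in place of 4-bromobenzyl on an amine nitrogen in a ring. Among the compounds with values here, the only measured step that bears on this position is the one from compound 1 to compound 2, and its size is not readable. For this assay no step beyond the scatter can be predicted in either direction from the change to compound 3. The estimate for compound 3 is 3000 nM with a range from 1000 nM to 10000 nM. The expected step is a step that the limit leaves unreadable from compound 2 to compound 3, and a limit rather than a number is again the most likely report.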

Compound 3, inhibition constant: > 1000 nM
Compound 3 was reported as a limit; the forecaster's own chance of this, stated with the estimate: 80%; the middle value is on the limit's open side.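

In this assay compound 3 gives only a limit, > 1000 nM. Going by these compounds alone, compound 1 and compound 2 are also limits, so no step among the three compounds can be read. The compounds shown leave open what inhibition constant any of them has in this assay, and whether the group on the ring amine nitrogen changes it at all.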